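Bicyclic acid replaces substituted benzoic acid on ring nitrogen

The source may report more compounds than this note shows. Statements on the series, on what has been measured and on what is new or still open speak of the compounds shown alone.

Measured compounds:
compound 1 `O=C(O)c1ccc2nc(CN3CCC[C@H](O[C@H](CO)c4cc(Cl)cc(Cl)c4)[C@@H]3c3ccccc3)[nH]c2c1` — 380 nM
compound 2 `O=C(O)c1ccc(CN2CCC[C@H](O[C@H](CO)c3cc(Cl)cc(Cl)c3)[C@@H]2c2ccccc2)c([N+](=O)[O-])c1` — 520 nM
compound 3 `O=C(O)c1ccc(CN2CCC[C@H](O[C@H](CO)c3cc(Cl)cc(Cl)c3)[C@@H]2c2ccccc2)c(C2CC2)c1` — 1800 nM

All three numbers come from an assay on isolated protein for activation of cGMP-dependent protein kinase 1 (Homo sapiens), read by ADP-Glo, with stated times of 30 min and 2 h, in the presence of a further agent that is not named here; on this read-out higher numbers stand for an effect only at larger amounts of compound and lower numbers for an effect already at smaller amounts. Compound 3 stands highest of the three: a 3.5-fold higher number from compound 2 to compound 3 (0.54 log units; beyond the scatter) and a 4.7-fold higher number from compound 1 to compound 3 (0.68 log units; beyond the scatter), both beyond the scatter but modest. Compound 1 and compound 2 lie within the scatter of each other, a 1.4-fold higher number from compound 1 to compound 2 (0.14 log units; within the scatter).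

Compound 4 `O=C(O)C12CC(CN3CCC[C@H](O[C@H](CO)c4cc(Cl)cc(Cl)c4)[C@@H]3c3ccccc3)(C1)C2` differs from compound 3 at the group on the saturated chain carbon bound to the amine nitrogen in the ring: a group of 8 heavy atoms (6 carbon, 2 oxygen; 2 four-membered non-aromatic rings of carbon only) in place of a group of 12 heavy atoms (10 carbon, 2 oxygen; one three-membered non-aromatic ring of carbon only, one six-membered aromatic ring of carbon only), on a saturated chain carbon bound to an amine nitrogen in a ring. The carboxylic acid remains; the six-membered aromatic ring of carbon only is gone, and two four-membered non-aromatic rings of carbon only carry the acid instead.

Among the measured compounds shown here, no measured step removes the aromatic ring from this group. The steps that touch it exchange one ring-bearing variant for another and stay modest, the largest being a 4.7-fold higher number from compound 1 to compound 3 (0.68 log units; beyond the scatter). A step of similar modest size in either direction is therefore plausible for compound 4, and the direction is open. Since a 3.5-fold higher number from compound 2 to compound 3 (0.54 log units; beyond the scatter) shows that removing the nitro for cyclopropyl raised the number, losing the cyclopropyl-bearing ring altogether is expected to give back some of that, so compound 4 is expected to come in at 900 nM, estimated between 250 nM and 4000 nM. The expected step is a 2.0-fold lower number from compound 3 to compound 4 (0.30 log units; within the scatter).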

Compound 4, half-maximal effective concentration: 12000 nM
Beside the measured number, compound 4's estimate is 13-fold (1.12 log units) below it; the whole stated range lies below it.
By their numbers in this assay, from the lowest: compounds 1 and 2 (each within the scatter of the next); then compound 3; then compound 4.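

In this assay, among the compounds shown here, the group with 2 four-membered non-aromatic rings of carbon only brings the first large steps at this place, on a saturated chain carbon bound to an amine nitrogen in a ring: a 23-fold higher number from compound 2 to compound 4 (1.36 log units; beyond the scatter) and a 32-fold higher number from compound 1 to compound 4 (1.50 log units; beyond the scatter), while a 6.7-fold higher number from compound 3 to compound 4 (0.82 log units; beyond the scatter) remains modest. Compound 4 keeps the carboxylic acid, so the acid alone does not hold the number at the level of the three groups with a six-membered aromatic ring of carbon only. Nothing available here accounts for this rise.

The aromatic ring and the heavy-atom count change together in these compounds, so a cyclohexane ring carrying the carboxylic acid would be needed to tell their contributions apart. Also open, going by these compounds, is how a tetrazole or a primary amide in place of the carboxylic acid would read at this place.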